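The compounds below may be only part of what the source reports. "The series", "measured", "known", "first", "only" and "open" are said of these compounds alone.

Compound 1 `CN(C)/C=N/c1c(C=O)c(-c2ccccc2)nn1-c1ccccc1` carries a dimethylamino group on a carbon with a double bond to nitrogen. In a functional assay on NPC-TW01 cells (Homo sapiens) for inhibition, read by MTT assay, with a stated time of 72 h (on this read-out higher numbers stand for weaker inhibition of growth and lower numbers for stronger inhibition of growth), compound 1 gives 9300 nM, the lowest of the three numbers recorded so far. Compound 2 `CN(C)/C=N/c1c(C=O)c(-c2ccccc2)nn1-c1ccccc1Cl` gives 23300 nM and compound 3 `CN(C)/C=N/c1c(C=O)c(-c2ccccc2)nn1-c1cccc([N+](=O)[O-])c1` gives 36700 nM. The two steps away from compound 1 are a 2.5-fold higher number from compound 1 to compound 2 (0.40 log units; beyond the scatter) and a 3.9-fold higher number from compound 1 to compound 3 (0.60 log units; beyond the scatter); both alter the aromatic ring on the nitrogen of the shared core, and the step of a 1.6-fold higher number from compound 2 to compound 3 (0.20 log units; within the scatter) between those two lies within the scatter. Compound 4 `O=Cc1c(-c2ccccc2)nn(-c2ccccc2)c1/N=C/N1CCCC1` differs from compound 1 in another place entirely: pyrrolidin-1-yl in place of dimethylamino on a carbon with a double bond to nitrogen. For the measured compounds named here, none of the measured steps touches the group on that carbon, so no recorded step bears directly on this change. The expectation therefore rests only on compound 1 itself, at 9300 nM in this assay. The step of no change at the digits printed from compound 1 to compound 4 (within the scatter) is expected to stay within the scatter, in no firm direction. Compound 4 is accordingly estimated at 9300 nM, within a range of 3500 nM to 25000 nM.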

Compound 4, concentration for 50% growth inhibition: > 50000 nM
Compound 4: a limit, no number; the forecaster's own chance of this, stated with the estimate: 5%; middle value at least 5.3-fold (0.73 log units) away from the limit.
By their numbers in this assay, from the lowest: compound 1; then compounds 2 and 3 (each within the scatter of the next). At a limit, above all of these: compound 4.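

The group on the carbon with a double bond to nitrogen is a second place in the series that responds: in this assay, pyrrolidin-1-yl in place of dimethylamino gives an at least 5.3-fold higher number from compound 1 to compound 4 (0.73 log units; beyond the scatter). All earlier steps changed only the aromatic ring on the nitrogen of the shared core, so they gave no sign of how this group affects growth inhibition. The result for compound 4 is a limit and not a number, so the step has a lower bound only: the limit of > 50000 nM in this assay, at which 1 of the 4 values shown sits.

On these data alone, whether the ring itself or the added carbons matter stays open, and diethylamino or piperidin-1-yl on the same carbon would help separate the two. Also open, as far as these compounds go, is how pyrrolidin-1-yl behaves alongside the chloro or nitro group on the aromatic ring.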